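Amide in Place of Sulfonamide on a Biaryl Scaffold

The source may report more compounds than this note shows. Statements on the series, on what has been measured and on what is new or still open speak of the compounds shown alone.

Of the compounds shown here, three have so far been measured in an assay on COS-7 cells for inhibition of patatin-like phospholipase domain-containing protein 2 (Mus musculus), tested at 200 uM; a higher number here means more inhibition at the concentration tested (going by the name of the read-out), a lower number less inhibition. Compound 1, `CCOC(=O)c1cccc(-c2ccc(CN(C)C)cc2)c1`, gives 67% in this assay. Compound 2, `CCOC(=O)c1cccc(-c2ccc3c(c2)CCN3)c1`, gives 66%. Compound 3, `CCOc1ccc(-c2cccc(S(=O)(=O)NC)c2)cc1`, gives 47%, the lowest of the three numbers: compound 2 lies nearest to it, yet beyond the scatter, and compound 1 lies furthest, also beyond the scatter. The account now turns from compound 3 to compound 4, `CCOc1ccc(-c2cccc(C(=O)NC)c2)cc1`, which has not yet been measured. The two structures differ in a single place: methylcarbamoyl in place of methylsulfamoyl on an aromatic carbon. For the measured compounds named here, no pair of measured compounds shows this change, so nothing measured tells how large a step it brings in this assay, and the expectation rests on compound 3 alone. Compound 4 is expected to give about 50%, with a range from 30% to 70%. The step of a number 3 percentage points higher from compound 3 to compound 4 (within the scatter) is estimated to fall within the usual scatter, in no firm direction.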

Compound 4, a percentage reported as inhibition, at one concentration (the size of the read-out at that concentration, not a potency): 40%
Compound 4: middle estimate off by 10 percentage points, on the high side, within the range that was stated.
By their numbers in this assay, from the lowest: compounds 4 and 3 (each within the scatter of the next); then compounds 2 and 1 (each within the scatter of the next).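

In this assay, for the compounds shown here, the exchange of methylsulfamoyl for methylcarbamoyl on an aromatic carbon gives a number 7 percentage points lower from compound 3 to compound 4 (within the scatter), the first step that isolates a single place, and at this place the two groups cannot be told apart by this read-out. Each group carries a hydrogen-bond donor, while methylcarbamoyl has fewer heavy atoms and hydrogen-bond acceptors, and these differences come with a step no larger than the scatter. Nothing at hand accounts for this step.

On these data alone, a carboxylic acid or a primary amine on this aromatic carbon, or a longer chain on the amide nitrogen in place of methyl, remains open. A single-concentration percentage also leaves the potency of compound 3 and compound 4 unknown.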